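The source may report more compounds than this note shows. Statements on the series, on what has been measured and on what is new or still open speak of the compounds shown alone.

Measured in a functional assay on HL-60 cells (Homo sapiens) for antiproliferative activity, read by MTT assay, with a stated time of 24 h; a lower number here means a stronger inhibitor, a higher number a weaker inhibitor:
Compound 1 `CCCCc1oc2ccccc2c1C(=O)c1ccc(OCC(=O)NC(C)C)cc1`: 360 nM
Compound 2 `CCCCc1oc2ccccc2c1C(=O)c1ccc(OCC(=O)N[C@H](C)c2ccccc2)cc1`: > 50000 nM (a limit)

Compound 2 stands at the limit of > 50000 nM in this assay, at which 1 of the 2 values shown sits. Its entry is a limit and not a number. Compound 3 `CCCCc1oc2ccccc2c1C(=O)c1ccc(OCCCC(=O)N2CCCC2)cc1` differs from compound 2 by one change, 2-((pyrrolidin-1-yl)carbonyl)ethyl in place of (1-phenylethyl)carbamoyl on a saturated chain carbon bound to an oxygen on an aromatic ring: 2-((pyrrolidin-1-yl)carbonyl)ethyl in place of (1-phenylethyl)carbamoyl. Among the measured compounds shown here, one measured step bears on this, the large at least 130-fold higher number from compound 1 to compound 2 (2.14 log units; beyond the scatter), where 1-phenylethyl replaced isopropyl on an amide-type nitrogen. Compound 3 lacks that 1-phenylethyl group, so a large step towards a lower number is expected in this assay. The estimated step is an at least 25-fold lower number from compound 2 to compound 3 (1.39 log units; beyond the scatter). For compound 3 the expected value is 2000 nM, with an estimated range of 300 nM to 15000 nM.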

Compound 3, half-maximal inhibitory concentration: 29900 nM
For compound 3 the middle estimate is 15-fold (1.17 log units) below the measured one; the measured number lies above the stated range.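

In this assay, 2-((pyrrolidin-1-yl)carbonyl)ethyl in place of isopropylcarbamoyl gives an 83-fold higher number from compound 1 to compound 3 (1.92 log units; beyond the scatter), so a large loss at this place does not need the 1-phenylethyl group. Replacing (1-phenylethyl)carbamoyl with the same group gives an at least 1.6-fold lower number from compound 2 to compound 3 (0.22 log units; that floor lies within the scatter), so no gain beyond the scatter can be claimed. The entry for compound 2 is a limit and not a number: the limit of > 50000 nM in this assay, at which 1 of the 3 values shown sits.

The compounds shown leave open which part of the change carries the loss: the longer chain, the pyrrolidine ring or the missing amide hydrogen. They also leave open how a morpholine amide or a carboxylic acid would fare at this place.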